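The source may hold more compounds than are shown below. What is called first, only, known or untested is meant among the compounds shown, and "the series" means these compounds.

Measured so far:
- compound 1, `NC(=O)CC[C@H](N)C(=O)NS(=O)(=O)OC[C@H]1O[C@@H](n2cnc3c(N)ncnc32)[C@H](O)[C@@H]1O`: 800 nM
- compound 2, `Nc1ncnc2c1ncn2[C@@H]1CO[C@H](COS(=O)(=O)NC(=O)[C@@H]2CCCN2)[C@@H](O)C1`: 2800 nM
- compound 3, `CC(C)C[C@H](N)C(=O)NS(=O)(=O)OC[C@H]1OC[C@@H](n2cnc3c(N)ncnc32)[C@H](O)[C@@H]1O`: 1000 nM

These three compounds were tested in a functional assay on PBMC cells (Homo sapiens) for inhibition; on this read-out higher numbers stand for weaker inhibition and lower numbers for stronger inhibition. Compound 1 gives the lowest of the three numbers in this assay. Its nearest neighbour is compound 3, whose value lies within the usual scatter of compound 1, so the two cannot be told apart. Compound 2 stands further away, beyond the scatter, with a clearly higher number than compound 1.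

The next compound, compound 4, `Nc1ncnc2c1ncn2[C@@H]1O[C@H](COS(=O)(=O)NC(=O)[C@@H]2CCCN2)[C@@H](O)[C@H]1O`, has not yet been measured. Compared with compound 1 it differs in one place: pyrrolidin-2-yl in place of 1-amino-3-carbamoylpropyl on a carbonyl carbon. The rest of the molecule stays as in compound 1.

Among the compounds with values here, no directly comparable pair has been measured, so the size of this step is open. Compound 2 carries the same pyrrolidin-2-yl group on its carbonyl, yet sits on a different core, and gives 2800 nM in this assay. Taking that together with the value of compound 1, I expect the step from compound 1 to compound 4 to be modest, probably within or only slightly beyond the scatter, and in either direction, no change at the digits printed from compound 1 to compound 4 (within the scatter). For compound 4 I estimate a value of 800 nM, with a range from 200 nM to 3000 nM.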

Compound 4, half-maximal inhibitory concentration: 700 nM
Beside the measured number, compound 4's estimate is 1.1-fold (0.06 log units) above it; low and high end bracket the measured number.
By their numbers in this assay, from the lowest: compounds 4, 1 and 3 (each within the scatter of the next); then compound 2.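

In this assay, exchanging the group on the carbonyl carbon gives a 1.1-fold lower number from compound 1 to compound 4 (0.06 log units; within the scatter), so on the core of compound 1 these two groups cannot be told apart. Within the data shown here, this is the first direct comparison at this position, and it shows that the open chain with its carbamoyl end can give way to a five-membered non-aromatic ring with no step beyond the scatter, even though the entering group has fewer heavy atoms and fewer hydrogen-bond donors and acceptors. Nothing in the available data explains why the two groups read alike.

Among these compounds, with only two groups compared at this position, it remains open whether a carboxylic acid at the end of the chain, a longer chain or a simple methyl on the carbonyl carbon would read the same. The compounds shown also include no pair that differs only in the core, so the part played by the core in the higher number of compound 2 remains open.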